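Trading 4-Ethylphenyl for 3-Methylphenyl: an Estimate

The source may report more compounds than this note shows. Statements on the series, on what has been measured and on what is new or still open speak of the compounds shown alone.

Of the compounds shown here, three sharing one core have been tested in a functional assay on UACC-62 cells (Homo sapiens) for inhibition, read by sulforhodamine B assay, with a stated time of 48 h, tested at 10 uM; a higher number here means more inhibition at the concentration tested (going by the name of the read-out), a lower number less inhibition. Compound 1 `Brc1cn2ccnc2c(-c2ccc3ncn(C4CCCCC4)c3c2)n1` gives 19.8%. Compound 2 `c1csc(-c2cn3ccnc3c(-c3ccc4ncn(C5CCCCC5)c4c3)n2)c1` gives 24.8%. Within the data shown here, the only single change between measured compounds, thiophen-2-yl in place of bromo on an aromatic carbon, yields a number 5 percentage points higher from compound 1 to compound 2 (within the scatter). Compound 3 `CCc1ccc(-c2cn3ccnc3c(-c3ccc4ncn(Cc5ccccc5)c4c3)n2)cc1` gives 24.9%, the highest of the three numbers, yet its gaps to compound 2 and to compound 1 both lie within the scatter, so none of the three can be ranked against another.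

Compound 4 `Cc1cccc(-c2cn3ccnc3c(-c3ccc4ncn(Cc5ccccc5)c4c3)n2)c1` has not yet been measured. It differs from compound 3 in one place: 3-methylphenyl in place of 4-ethylphenyl on an aromatic carbon. Among the measured compounds shown here, no measured step alters the same kind of group; the single known step concerns a different part of the core and stays within the scatter. With the three measured numbers lying close together and no step beyond the scatter seen so far, no shift beyond the scatter is expected here either. The expected step is a number 0.1 percentage points higher from compound 3 to compound 4 (within the scatter). Compound 4 is therefore estimated at 25%, with a range from 12% to 38%.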

Compound 4, a percentage reported as inhibition, at one concentration (the size of the read-out at that concentration, not a potency): 2.46%
Compound 4: middle estimate off by 22.5 percentage points, on the high side, outside the stated range (below it).
By their numbers in this assay, from the lowest: compound 4; then compounds 1, 2 and 3 (each within the scatter of the next).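

In this assay, among these compounds, the swap of 4-ethylphenyl for 3-methylphenyl gives a number 22.4 percentage points lower from compound 3 to compound 4 (beyond the scatter) and is the first step to go beyond the scatter, while the only earlier step, a number 5 percentage points higher from compound 1 to compound 2 (within the scatter) and no more, stayed within it. This shows that the read-out can respond to a small edit of the aromatic group on this carbon of the shared core, even though the group keeps its single six-membered aromatic ring and goes only from 8 heavy atoms to 7. Nothing available explains why the number falls so far with this change.

The step alters two things at once, the length of the alkyl group and its place on the phenyl ring, so the compounds shown cannot tell which of the two matters, and 4-methylphenyl or 3-ethylphenyl would be the groups that separate them. As far as these compounds go, whether unsubstituted phenyl, or a ring carrying an amine or a carboxylic acid, would stay near compound 3 or near compound 4 also remains open.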